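Swapping Ethyl for Trifluoromethyl on a Weak Inhibitor

A few compounds are considered here, and "the series" means these few. Any claim that something is new, unique, unknown or untested is made for them only; others in the source may bear on it.

Of the compounds shown here, three have been measured in an assay on isolated protein for inhibition of Intestinal-type alkaline phosphatase (Bos taurus), read by spectrophotometry, with stated times of 7 min and 15 min; a lower number here means a stronger inhibitor, a higher number a weaker inhibitor. Compound 1, `CCCCCc1cc(=O)c2cc([N+](=O)[O-])ccc2n1Cc1ccc(OC)cc1`, gives 1380 nM. Compound 2, `Cc1ccc(-c2c(Br)c(=O)c3cc([N+](=O)[O-])ccc3n2C(C)c2ccccc2)cc1`, gives 2470 nM. Compound 3, `CCc1ccc(-c2c(-c3ccc(C)cc3)n(Cc3ccc(OC)cc3)c3ccc([N+](=O)[O-])cc3c2=O)cc1`, gives 5750 nM, the highest number of the three; its gap to compound 2 and its larger gap to compound 1 both lie beyond the usual scatter, so compound 3 is the weakest inhibitor measured so far.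

Compound 4, `COc1ccc(Cn2c(-c3ccc(C)cc3)c(-c3ccc(C(F)(F)F)cc3)c(=O)c3cc([N+](=O)[O-])ccc32)cc1`, differs from compound 3 in one place: trifluoromethyl in place of ethyl on an aromatic carbon. Among the measured compounds shown here, no pair among the measured compounds differs in just this way, so there is no measured step to lean on; the expectation rests only on the size of the change and on where compound 3 stands. An exchange of one small group for another on an aromatic carbon, with no change in the count of hydrogen-bond donors or acceptors, is expected to move the number little. The step from compound 3 to compound 4 in this assay is therefore expected to be a 1.2-fold lower number from compound 3 to compound 4 (0.06 log units; within the scatter), not clearly beyond the scatter in either direction. Compound 4 is expected to give about 5000 nM in this assay, with a likely range from 1800 nM to 14000 nM.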

Compound 4, half-maximal inhibitory concentration: 8340 nM
Estimate against measurement, compound 4: 1.7-fold (0.22 log units) below; measured number inside the range.
By their numbers in this assay, from the lowest: compounds 1 and 2 (each within the scatter of the next); then compounds 3 and 4 (each within the scatter of the next).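

In this assay, replacing 4-ethylphenyl with 4-(trifluoromethyl)phenyl gives a 1.5-fold higher number from compound 3 to compound 4 (0.16 log units; within the scatter). Among the compounds shown here, this is the first measured pair here that differs in only one place, and it shows that this exchange, on an aromatic carbon para to a large group, does not separate the two compounds: a group of 2 heavy atoms gives way to one of 4, and the difference in the read-out stays within what repeated measurements would produce. No measurement shown here explains why the two compounds read alike.

For the compounds shown here, this single step covers only one exchange at one place, so it cannot show whether the place tolerates change in general: a carboxylic acid, an amine or a longer chain on the same aromatic carbon might still move the number beyond the scatter. It also leaves open whether the same exchange of ethyl for trifluoromethyl would have so small an effect on a compound that differs elsewhere, such as one with a different group on the ring nitrogen.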